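The source may hold more compounds than are shown below. What is called first, only, known or untested is meant among the compounds shown, and "the series" means these compounds.

The series shares the core of compound 1 `C=C[C@@](C)(/C=C/c1ccc(OC)cc1)CCC=C(C)C` and is followed in an ADME assay on HEK293 cells (Homo sapiens) for cytotoxicity, with a stated time of 72 h; on this read-out lower numbers stand for an effect already at smaller amounts and higher numbers for an effect only at larger amounts of compound. Compound 1 gives only a limit there, > 36600 nM. Compound 2 `C=C[C@@](C)(/C=C/c1ccc(O)c(CO)c1)CCC=C(C)C` likewise returns a limit, > 36600 nM. Compound 3 `C=C[C@@](C)(/C=C/c1ccc(O)c(/C=C/C(=O)OCC)c1)CCC=C(C)C` also returns a limit, > 36600 nM. Among the measured compounds shown here, the one single-point step among the measured compounds, a step that the two limits leave unreadable from compound 2 to compound 3, therefore carries no readable size. Taken together, (the limit of > 36600 nM in this assay, at which 3 of the 3 values shown sit), so no measured step in this assay has a magnitude that could be carried over. Compound 4 `C=C[C@@](C)(/C=C/c1ccc(Nc2ccc(Cl)c(Cl)c2)cc1)CCC=C(C)C` differs from compound 1 by (3,4-dichlorophenyl)amino in place of methoxy on an aromatic carbon. No measured pair touches the methoxy of compound 1, and the only measured step is unreadable, so the step that the limit leaves unreadable from compound 1 to compound 4 is expected to stay within the scatter, with nothing shown that would push it either way. Compound 4 is expected to give 40000 nM, in the range 10000 nM to 150000 nM, most probably again as a limit rather than a number.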

Compound 4, half-maximal effective concentration: > 36600 nM
Compound 4: a limit, no number; the forecaster's own chance of this, stated with the estimate: 70%; the middle value lies beyond the limit too.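

Among the compounds shown here, compound 4 returns only a limit, > 36600 nM, so its step from compound 1 cannot be read, and no new step emerges: the limit of > 36600 nM in this assay, at which 4 of the 4 values shown sit. The compounds shown leave open at what concentration, if any, a member of this series produces an effect in this assay.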